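Extending the aminoalkyl chain of compound 2

The source may report more compounds than this note shows. Statements on the series, on what has been measured and on what is new or still open speak of the compounds shown alone.

Among the compounds with values here, in a functional assay on MCF7 cells (Homo sapiens) for cytotoxicity, read by MTT assay, with a stated time of 72 h (on this read-out lower numbers stand for stronger inhibition and higher numbers for weaker inhibition), compound 1 (`N[C@H]1CC[C@H](Nc2c(C(=O)NCc3ccc(F)cc3)nc(Br)c3cccnc23)CC1`) gives 2000 nM and compound 2 (`NCCNc1c(C(=O)NCc2ccc(F)cc2)nc(Br)c2cccnc12`) gives 6000 nM, the higher of the two numbers so far. Compound 3 (`NCCCCCCNc1c(C(=O)NCc2ccc(F)cc2)nc(Br)c2cccnc12`) differs from compound 2 by 4-aminobutyl in place of amino on a saturated chain carbon, two bonds along the chain from a nitrogen on an aromatic ring, so that 2-aminoethyl becomes 6-aminohexyl. Within the data shown here, only one measured step bears on this change: a 3.0-fold higher number from compound 1 to compound 2 (0.48 log units; beyond the scatter), a modest step at the same place. No straight chain longer than 2-aminoethyl has been measured, so only a small move toward a lower number is expected in this assay. The expected step is a 2.0-fold lower number from compound 2 to compound 3 (0.30 log units; within the scatter). For compound 3 the estimated value is 3000 nM, with an expected range of 1000 nM to 9000 nM.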

Compound 3, half-maximal inhibitory concentration: 2000 nM
The estimate for compound 3 lay 1.5-fold (0.18 log units) above the measured number; low and high end bracket the measured number.
By their numbers in this assay, from the lowest: compounds 1 and 3 (each within the scatter of the next); then compound 2.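

In this assay, replacing 2-aminoethyl with 6-aminohexyl gives a 3.0-fold lower number from compound 2 to compound 3 (0.48 log units; beyond the scatter) and so shows that chain length at this position can shift the number. The straight chain also compares with the 4-aminocyclohexyl group of compound 1, with no change at the digits printed from compound 1 to compound 3 (within the scatter) from the ring-bearing group to the open chain, so among these compounds a ring at this position is not needed to reach this level. No evidence on the cause of either result is available.

Going by these compounds, whether intermediate chains such as 4-aminobutyl follow the same trend remains open. Also open, on these data alone, are the effects of a longer chain and of a hydroxyl group in place of the terminal amine.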